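The source may hold more compounds than are shown below. What is called first, only, known or untested is meant among the compounds shown, and "the series" means these compounds.

Measured so far in an assay on BaF3 cells for displacement of a labelled ligand from C-X-C chemokine receptor type 1 (Homo sapiens); a lower number here means a stronger inhibitor, a higher number a weaker inhibitor: compound 1 `Cc1ccc([C@@H](C)Nc2c(Nc3cccc(C(=O)N(C)C)c3O)c(=O)c2=O)o1` gives 775 nM; compound 2 `Cc1ccc([C@H](Nc2c(Nc3cccc(C(=O)N(C)C)c3O)c(=O)c2=O)C(C)C)o1` gives 34 nM. Compound 2 stands lowest of the two numbers, and the step of a 23-fold lower number from compound 1 to compound 2 (1.36 log units; beyond the scatter) is the only one known.

Compound 3 `Cc1ccc([C@H](Nc2c(Nc3cccc(C(=O)N(C)C)c3O)c(=O)c2=O)C(C)(C)C)o1` carries methyl in place of hydrogen on a saturated chain carbon bound to three saturated chain carbons. Among the measured compounds shown here, the one step that bears on it, a 23-fold lower number from compound 1 to compound 2 (1.36 log units; beyond the scatter), was large and in the direction of a lower number, so a further enlargement at the same carbon may go either way, and no step beyond the scatter is firmly expected. Compound 3 is estimated at 30 nM (range 8 nM to 120 nM), i.e. an expected step of a 1.1-fold lower number from compound 2 to compound 3 (0.05 log units; within the scatter).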

Compound 3, half-maximal inhibitory concentration: 11 nM
Beside the measured number, compound 3's estimate is 2.7-fold (0.44 log units) above it; low and high end bracket the measured number.
By their numbers in this assay, from the lowest: compound 3; then compound 2; then compound 1.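

In this assay, enlarging the group on the saturated chain carbon bound to an aromatic carbon and a nitrogen on an aromatic ring still lowers the number after isopropyl, as isopropyl to tert-butyl gives a further, modest drop (a 3.1-fold lower number from compound 2 to compound 3 (0.49 log units; beyond the scatter)). Across the three compounds, tert-butyl in place of methyl gives the full change (a 70-fold lower number from compound 1 to compound 3 (1.85 log units; beyond the scatter)), and no reversal appears up to tert-butyl. No evidence on why this happens is available. Open, going by these compounds, are a cyclohexyl ring or a longer chain such as neopentyl at this carbon, and whether an amine or a carboxylic acid there would fit the same trend.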